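A few compounds are considered here, and "the series" means these few. Any claim that something is new, unique, unknown or untested is made for them only; others in the source may bear on it.

Measured in a functional assay for inhibition, read by fluorescence and spectrophotometry, with a stated time of 30 h; a lower number here means a stronger inhibitor, a higher number a weaker inhibitor:
- compound 1 `COc1ccc(-c2cc(=O)c3ccc(OCCCN4CCC(C)CC4)cc3o2)cc1`: 42600 nM
- compound 2 `COc1ccc(-c2cc(=O)c3ccc(OCCCCN4CCC(C)CC4)cc3o2)cc1`: 48200 nM
- compound 3 `COc1ccc(-c2cc(=O)c3ccc(OCCCCCN4CCC(C)CC4)cc3o2)cc1`: 55100 nM

Compound 2 cannot be told apart from the other two compounds, because its values lie within the usual scatter of both: a 1.1-fold higher number from compound 1 to compound 2 (0.05 log units; within the scatter), and a 1.1-fold higher number from compound 2 to compound 3 (0.06 log units; within the scatter). All three compounds therefore form a single flat group in this assay, and the small differences among them should not be read as a ranking.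

The unmeasured compound 4 `COc1ccc(-c2cc(=O)c3ccc(OCCCCCCN4CCC(C)CC4)cc3o2)cc1` differs from compound 2 in one place: 2-(4-methylpiperidin-1-yl)ethyl in place of 4-methylpiperidin-1-yl on a saturated chain carbon, four bonds along the chain from an oxygen on an aromatic ring. Put simply, 2-(4-methylpiperidin-1-yl)ethyl stands in place of 4-methylpiperidin-1-yl, on a saturated chain carbon, four bonds along the chain from an oxygen on an aromatic ring.

Going by the values given here, the closest precedent is the same swap made three bonds along the chain: a 1.3-fold higher number from compound 1 to compound 3 (0.11 log units; within the scatter). That step also stays within the scatter, as do the two smaller steps. On these data alone, no compound beyond compound 3 has been measured, so the behaviour of this series past that point is untested. No step beyond the scatter is expected, and the estimated change is a 1.2-fold higher number from compound 2 to compound 4 (0.10 log units; within the scatter).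

For compound 4 the expected value is 60000 nM, with an estimated range from 33000 nM to 105000 nM.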

Compound 4, half-maximal inhibitory concentration: 57200 nM
Compound 4: the middle estimate sits 1.0-fold (0.02 log units) above what was measured; measured number inside the range.
By their numbers in this assay, from the lowest: compounds 1, 2, 3 and 4 (each within the scatter of the next).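

In this assay, the flat picture now reaches the longest chain shown: a 1.2-fold higher number from compound 2 to compound 4 (0.07 log units; within the scatter), a 1.0-fold higher number from compound 3 to compound 4 (0.02 log units; within the scatter), and the largest step in the series, a 1.3-fold higher number from compound 1 to compound 4 (0.13 log units; within the scatter), also stays within the usual scatter of repeated measurements. Adding to the chain therefore gives no sign of a length at which the number clearly moves, and the same small steps recur when one change is read at two places on the chain. With (4-methylpiperidin-1-yl)methyl in place of 4-methylpiperidin-1-yl, and again with 2-(4-methylpiperidin-1-yl)ethyl in place of 4-methylpiperidin-1-yl, the two readings of each change agree: the same change on two cores in this assay, a 1.1-fold higher number (0.05 log units; within the scatter) from compound 1 to compound 2 and a 1.0-fold higher number (0.02 log units; within the scatter) from compound 3 to compound 4, 1.1-fold (0.04 log units) apart, within the scatter of two such steps; the same change on two cores in this assay, a 1.3-fold higher number (0.11 log units; within the scatter) from compound 1 to compound 3 and a 1.2-fold higher number (0.07 log units; within the scatter) from compound 2 to compound 4, 1.1-fold (0.04 log units) apart, within the scatter of two such steps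

All four compounds share the same 4-methylpiperidin-1-yl group, so these compounds cannot tell whether another amine in its place, such as morpholine or piperazine, would give a clearly different number. They also leave open whether a shorter chain, or a still longer one, would stay in this flat group.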